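Swapping the benzyl ether of compound 1 for a hexyloxy chain

The source may report more compounds than this note shows. Statements on the series, on what has been measured and on what is new or still open speak of the compounds shown alone.

Three anilides sharing one core have been measured in a functional assay on cells (Homo sapiens) for cytotoxicity, read by MTT assay, with a stated time of 72 h; on this read-out higher numbers stand for weaker inhibition and lower numbers for stronger inhibition. Compound 1 `Cc1ccc(C)c(COc2cc(NC(=O)C3CCCCC3)ccc2N(C)S(C)(=O)=O)c1` gives 2660 nM in this assay. Compound 2 `Cc1ccc(C)c(COc2cc(NC(=O)c3ccccc3)ccc2N(C)S(C)(=O)=O)c1` gives 4680 nM, and compound 3 `CN(c1ccc(NC(=O)c2ccccc2)cc1OCc1cc(Cl)ccc1Cl)S(C)(=O)=O` gives 2150 nM. For the measured compounds named here, compound 1 thus stands second highest of the three numbers, within the scatter of both compound 3 and compound 2; the step of a 1.8-fold higher number from compound 1 to compound 2 (0.25 log units; within the scatter) and the step of a 2.2-fold lower number from compound 2 to compound 3 (0.34 log units; beyond the scatter) are the only single changes on record.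

Compound 4 `CCCCCCOc1cc(NC(=O)C2CCCCC2)ccc1N(C)S(C)(=O)=O` differs from compound 1 by pentyl in place of 2,5-dimethylphenyl on a saturated chain carbon bound to an oxygen on an aromatic ring. Going by the values given here, the step from compound 2 to compound 3 touches the same place, but it exchanges one aromatic group for another, whereas here the ring leaves altogether and a pentyl chain enters; no measured step tests such an exchange. The account therefore expects a step of a 1.5-fold higher number from compound 1 to compound 4 (0.18 log units; within the scatter) in this assay, a somewhat higher number that may well lie within the scatter. Compound 4 is estimated at 4000 nM, with a range from 1500 nM to 11000 nM.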

Compound 4, half-maximal inhibitory concentration: 6980 nM
For compound 4 the middle estimate is 1.7-fold (0.24 log units) below the measured one; the measured number falls inside the stated range.
By their numbers in this assay, from the lowest: compounds 3, 1, 2 and 4 (each within the scatter of the next, the first and the last beyond it).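

In this assay, pentyl in place of 2,5-dimethylphenyl on a saturated chain carbon bound to an oxygen on an aromatic ring gives a 2.6-fold higher number from compound 1 to compound 4 (0.42 log units; beyond the scatter), so removing the aromatic ring at this position moves the number beyond the scatter. For the compounds shown here, the only earlier step at this place, a 2.2-fold lower number from compound 2 to compound 3 (0.34 log units; beyond the scatter), exchanged one aromatic group for another and could not show what happens when the ring leaves altogether. Nothing on record explains this single-pair result.

From the compounds shown here alone, it remains open whether the higher number follows from losing the ring, from losing its aromatic character or from the length of the chain. A cyclohexyl group in the same place, or a shorter chain such as butyl, would help to separate these readings.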